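Swapping a Bridged Ether for an Aminopyrrolidine

The compounds below may be only part of what the source reports. "The series", "measured", "known", "first", "only" and "open" are said of these compounds alone.

Measured compounds:
compound 1 `CC(C)N(C)c1ccc2cc(NC(=O)CCc3ccc(C(F)(F)F)cc3)ccc2n1` — 140 nM
compound 2 `O=C(CCc1ccc(C(F)(F)F)cc1)Nc1ccc2nc(N3CCC(c4ccccc4)C3)ccc2c1` — 1770 nM
compound 3 `O=C(CCc1ccc(C(F)(F)F)cc1)Nc1ccc2nc(N3CC4CC3CO4)ccc2c1` — 70 nM

In a functional assay on HEK293 cells for activation of melanin-concentrating hormone receptor 1 (Rattus norvegicus), read by inositol phosphate accumulation (a lower number here means that less compound is needed, a higher number that more compound is needed for the effect), compound 3 gives the lowest of the three numbers. Its lead over compound 1 is small, as the step of a 2.0-fold lower number from compound 1 to compound 3 (0.30 log units; within the scatter) lies within the scatter, whereas the step of a 25-fold lower number from compound 2 to compound 3 (1.40 log units; beyond the scatter) is large. The unmeasured compound 4 `NC1CCN(c2ccc3cc(NC(=O)CCc4ccc(C(F)(F)F)cc4)ccc3n2)C1` differs from compound 3 by a group of 6 heavy atoms (4 carbon, 2 nitrogen; one five-membered non-aromatic ring with 1 hetero atom) in place of a group of 7 heavy atoms (5 carbon, 1 nitrogen, 1 oxygen; 2 five-membered non-aromatic rings with 1 hetero atom each), on an aromatic carbon.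

Among the compounds with values here, two measured steps bear on this position. The step of a 13-fold higher number from compound 1 to compound 2 (1.10 log units; beyond the scatter) shows that a pyrrolidine carrying a phenyl ring costs a great deal, while the step of a 2.0-fold lower number from compound 1 to compound 3 (0.30 log units; within the scatter) shows that exchanging a small acyclic amine for the bridged ether changes little. Within the data shown here, compound 4 carries a pyrrolidine without the phenyl ring, and its amino group has no direct counterpart among the measured compounds. The bulk that hurt in compound 2 is absent, so a modest step is expected: a 1.6-fold higher number from compound 3 to compound 4 (0.20 log units; within the scatter), with the number for compound 4 estimated at 110 nM, in a range from 35 nM to 350 nM.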

Compound 4, half-maximal effective concentration: 200 nM
Beside the measured number, compound 4's estimate is 1.8-fold (0.26 log units) below it; the range from low to high includes it.
By their numbers in this assay, from the lowest: compounds 3, 1 and 4 (each within the scatter of the next, the first and the last beyond it); then compound 2.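

Putting amino in place of phenyl on the saturated ring carbon gives an 8.9-fold lower number from compound 2 to compound 4 (0.95 log units; beyond the scatter), so the large cost of compound 2 goes with the phenyl ring and not with the pyrrolidine ring alone. The step of a 1.4-fold higher number from compound 1 to compound 4 (0.15 log units; within the scatter) lies within the scatter, so 3-aminopyrrolidin-1-yl and the open-chain isopropyl(methyl)amino group cannot be told apart at this position. The step of a 2.9-fold higher number from compound 3 to compound 4 (0.46 log units; beyond the scatter) is modest but beyond the scatter, which makes this the first change among these compounds to separate the bridged ether group from another group of similar size.

Nothing measured here explains these differences. Still open, from the compounds shown here alone, is what the amino group itself contributes, which the plain pyrrolidin-1-yl group or a 3-hydroxypyrrolidin-1-yl group at the same position would help to show.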